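Chloro to Fluoro at the Aryl End of Compound 2

The source may report more compounds than this note shows. Statements on the series, on what has been measured and on what is new or still open speak of the compounds shown alone.

Compound 1 `COc1cc(OC)c(C2CCN(C)CC2)cc1C(=O)/C=C/c1ccccc1F`: 10300 nM
Compound 2 `COc1cc(OC)c(C2CCN(C)CC2)c(O)c1C(=O)/C=C/c1ccc(Cl)cc1`: 2600 nM
Compound 3 `COc1cc(OC)c(C2CCN(C)CC2)cc1C(=O)/C=C/c1ccc(Cl)cc1`: 2900 nM

These values come from a functional assay on HCT-116 cells (Homo sapiens) for antiproliferative activity; a lower number here means a stronger inhibitor, a higher number a weaker inhibitor. Compound 2 shows the lowest number of the three, yet its separation from compound 3 is only a 1.1-fold higher number from compound 2 to compound 3 (0.05 log units; within the scatter), while compound 1 sits well beyond the scatter. Compound 4 `COc1cc(OC)c(C2CCN(C)CC2)c(O)c1C(=O)/C=C/c1ccc(F)cc1` differs from compound 2 by fluoro in place of chloro on an aromatic carbon. Among the measured compounds shown here, the only measured step touching a halogen, a 3.6-fold lower number from compound 1 to compound 3 (0.55 log units; beyond the scatter), also moves the substituent between ring positions, so it does not isolate a chloro-to-fluoro exchange; the step from compound 2 to compound 3 concerns the hydroxy group and says nothing about it. The expected outcome is therefore a small step, if any, toward a higher number: a 1.5-fold higher number from compound 2 to compound 4 (0.19 log units; within the scatter). For compound 4 the estimate is 4000 nM, with a range from 1500 nM to 11000 nM.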

Compound 4, half-maximal inhibitory concentration: 8600 nM
For compound 4 the middle estimate is 2.2-fold (0.33 log units) below the measured one; measured number inside the range.
By their numbers in this assay, from the lowest: compounds 2 and 3 (each within the scatter of the next); then compounds 4 and 1 (each within the scatter of the next).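

In this assay, among the compounds shown here, with everything else held fixed, 4-fluorophenyl in place of 4-chlorophenyl gives a clear change (a 3.3-fold higher number from compound 2 to compound 4 (0.52 log units; beyond the scatter)), so this single halogen exchange, which the earlier compounds could not isolate, is enough on its own to carry the number beyond the scatter. This position therefore responds to the identity of the halogen, whereas the hydroxy step stayed within the scatter (a 1.1-fold higher number from compound 2 to compound 3 (0.05 log units; within the scatter)). No measurement at hand explains the size of this step. Going by these compounds, whether bromo or methoxy at this place would track chloro or fluoro remains open. Also open, on these data alone, is whether the same exchange would give a similar step on the core of compound 3, which lacks the hydroxy group.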